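The source may hold more compounds than are shown below. What is called first, only, known or untested is meant among the compounds shown, and "the series" means these compounds.

Measured so far in a functional assay on MCF7 cells (Homo sapiens) for antiproliferative activity, read by MTT assay, with a stated time of 72 h; a higher number here means a weaker inhibitor, a lower number a stronger inhibitor:
Compound 1 `CCOc1ccc(-c2ccc3ncn(-c4cc(OC)c(OC)c(OC)c4)c3c2)cc1`: 1710 nM
Compound 2 `COc1ccccc1-c1ccc2ncn(-c3cc(OC)c(OC)c(OC)c3)c2c1`: 1750 nM
Compound 3 `COc1cc(-n2cnc3ccc(-c4ccccc4Cl)cc32)cc(OC)c1OC`: > 10000 nM, a limit of the assay

Within the data shown here, only two exact numbers are available, and compound 2 sits level with compound 1, as the step shows: a 1.0-fold higher number from compound 1 to compound 2 (0.01 log units; within the scatter). Compound 3 is known only by its limit of > 10000 nM.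

Compound 4 `COc1cc(-n2cnc3ccc(-c4ccc(C(C)=O)cc4)cc32)cc(OC)c1OC` departs from compound 2 at one place: 4-acetylphenyl in place of 2-methoxyphenyl on an aromatic carbon. Here 4-acetylphenyl takes the place of 2-methoxyphenyl on an aromatic carbon.

Among the measured compounds shown here, no measured compound carries the 4-acetylphenyl group, so the evidence is indirect. Exchanging 4-ethoxyphenyl for 2-methoxyphenyl made no difference beyond the scatter, as a 1.0-fold higher number from compound 1 to compound 2 (0.01 log units; within the scatter) shows, which suggests that this place tolerates some variation. Compound 3 is the case against that reading, with an at least 5.8-fold higher number from compound 1 to compound 3 (0.76 log units; beyond the scatter) and an at least 5.7-fold higher number from compound 2 to compound 3 (0.75 log units; beyond the scatter), so a marked loss in this assay cannot be ruled out.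

The expected change is small and leans toward a weaker inhibitor, as the estimated step of a 1.4-fold higher number from compound 2 to compound 4 (0.15 log units; within the scatter) indicates. The range is kept wide on the weaker side. For compound 4 the estimated value is 2500 nM, with an expected range from 700 nM to 9000 nM.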

Compound 4, half-maximal inhibitory concentration: 1540 nM
Compound 4: middle estimate off by 1.6-fold (0.21 log units), on the high side, and the stated range covers the measured number.
By their numbers in this assay, from the lowest: compounds 4, 1 and 2 (each within the scatter of the next). At a limit, above all of these: compound 3.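

The steps of a 1.1-fold lower number from compound 2 to compound 4 (0.06 log units; within the scatter) and a 1.1-fold lower number from compound 1 to compound 4 (0.05 log units; within the scatter) put 4-acetylphenyl level with both 2-methoxyphenyl and 4-ethoxyphenyl in this assay, so this aromatic carbon of the shared core now carries three different substituted phenyl groups with no difference beyond the scatter. Compound 3, with 2-chlorophenyl, goes against this pattern, and the step of an at least 6.4-fold lower number from compound 3 to compound 4 (0.81 log units; beyond the scatter) shows that it stands apart from compound 4 as it does from compound 1 and compound 2, which makes it a single exception among four compounds and no longer one of only three. Compound 3 is known only by a limit, so the full size of its gap to the others cannot be read: the limit of > 10000 nM in this assay, at which 1 of the 4 values shown sits.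

The compounds shown leave open whether a 4-chlorophenyl group would read like compound 3 or like compound 4, and so whether the chloro group itself or its place on the phenyl ring goes with the loss. They also leave open whether the same level would hold for a phenyl group carrying an amine, a carboxylic acid or a longer chain.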